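Triazole substituent series: octyl to ethoxycarbonyl on compound 2

This account rests on a few compounds, and the source may have more. Where it says the series, first, only, none or still open, it means among the compounds named here.

The series shares one core, varied only at the five-membered ring with three nitrogens. Compound 1 `CCCCc1cn(C(c2ccccc2)c2cc3cc(Br)ccc3nc2OC)nn1` gives 11.1% in an ADME assay on SK-OV-3 cells (Homo sapiens) for cytotoxicity, read by sulforhodamine B assay, with a stated time of 48 h, tested at 10 uM; on this read-out lower numbers stand for less inhibition and higher numbers for more inhibition at the one concentration tested (going by the name of the read-out). Compound 2 `CCCCCCCCc1cn(C(c2ccccc2)c2cc3cc(Br)ccc3nc2OC)nn1` gives 2.06% in this assay, and compound 3 `COc1nc2ccc(Br)cc2cc1C(c1ccccc1)n1cc(CO)nn1` gives 3.23% in this assay. Compound 2 holds the lowest of the three numbers, but its steps to the others, a number 1.2 percentage points higher from compound 2 to compound 3 (within the scatter) and the reverse of a number 9 percentage points lower from compound 1 to compound 2 (within the scatter), both lie within the scatter, so no ordering among the three can be claimed.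

Compound 4 `CCOC(=O)c1cn(C(c2ccccc2)c2cc3cc(Br)ccc3nc2OC)nn1` is not yet measured. It differs from compound 2 in one place: ethoxycarbonyl in place of octyl on an aromatic carbon. The step bearing on this most directly is the exchange of a chain for a small oxygen-bearing group, a number 1.2 percentage points higher from compound 2 to compound 3 (within the scatter), which was within the scatter; the chain-length step a number 9 percentage points lower from compound 1 to compound 2 (within the scatter) and the step of a number 7.9 percentage points lower from compound 1 to compound 3 (within the scatter) were likewise within the scatter. Within the data shown here, every change at this position so far has left this assay essentially unmoved.

Compound 4 is therefore expected to show no step beyond the scatter, a number 3.9 percentage points higher from compound 2 to compound 4 (within the scatter). The estimate for compound 4 is 6% in this assay, with a range from 0% to 18%.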

Compound 4, a percentage reported as inhibition, at one concentration (the size of the read-out at that concentration, not a potency): 2.01%
Compound 4: middle estimate off by 4 percentage points, on the high side; measured number inside the range.
By their numbers in this assay, from the lowest: compounds 4, 2, 3 and 1 (each within the scatter of the next).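

On the aromatic carbon of the five-membered aromatic ring with 3 nitrogen, the series now includes a group with a carbonyl, and ethoxycarbonyl in place of octyl gives a number 0.1 percentage points lower from compound 2 to compound 4 (within the scatter) in this assay without separating from the long chain. Ethoxycarbonyl also stays within the scatter of the other two substituents, with a number 1.2 percentage points lower from compound 3 to compound 4 (within the scatter) against hydroxymethyl and a number 9.1 percentage points lower from compound 1 to compound 4 (within the scatter) against butyl, so across alkyl chains, hydroxymethyl and a carbonyl-bearing group at this position the number stays level, with no step beyond the scatter in this assay among these four compounds. No supporting data bear on why the number stays unmoved across these exchanges.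

On these data alone, whether an amine, a carboxylic acid or a chain longer than octyl on this aromatic carbon would give a step beyond the scatter remains open. As far as these compounds go, with a single concentration and a single cell line behind these numbers, it is also open whether the four compounds would separate at a higher concentration or on other cells, so the flat picture applies only to these conditions.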